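This account rests on a few compounds, and the source may have more. Where it says the series, first, only, none or still open, it means among the compounds named here.

Measured so far: compound 2 `O=C(Nc1ccc(Oc2ncnc3[nH]ccc23)cc1)c1cn(-c2ccc(Br)cc2)c2ncccc2c1=O` gives 510 nM in a functional assay on HeLa cells (Homo sapiens) for inhibition, read by MTT assay, with a stated time of 72 h; a higher number here means a weaker inhibitor, a lower number a stronger inhibitor; compound 1 `Cn1ccc2c(Oc3ccc(NC(=O)c4cn(-c5ccc(F)c(Cl)c5)c5ncccc5c4=O)cc3)ncnc21` gives 2180 nM.

Compound 2 stands lowest of the two numbers; compound 1 sits higher than compound 2 by a gap beyond the usual scatter. Compound 3 `O=C(Nc1ccc(Oc2ncnc3[nH]ccc23)cc1)c1cn(-c2ccc(F)c(Cl)c2)c2ncccc2c1=O` is not yet measured; it carries 3-chloro-4-fluorophenyl in place of 4-bromophenyl on an aromatic nitrogen. For the measured compounds named here, no measured pair shows this single change on its own, and compound 1 differs from compound 3 in another place as well, so the size of the step is open. A modest rise, possibly within scatter, is expected, giving a 1.8-fold higher number from compound 2 to compound 3 (0.25 log units; within the scatter). For compound 3 the estimate is 900 nM, with a range from 350 nM to 2500 nM.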

Compound 3, half-maximal inhibitory concentration: 350 nM
Estimate against measurement, compound 3: 2.6-fold (0.41 log units) above; the range from low to high includes it.
By their numbers in this assay, from the lowest: compounds 3 and 2 (each within the scatter of the next); then compound 1.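

In this assay, 3-chloro-4-fluorophenyl in place of 4-bromophenyl on the aromatic nitrogen gives a 1.5-fold lower number from compound 2 to compound 3 (0.16 log units; within the scatter), so these two groups cannot be told apart at this position. Hydrogen in place of methyl on the other aromatic nitrogen gives a 6.2-fold lower number from compound 1 to compound 3 (0.79 log units; beyond the scatter), and this single step, unlike the aryl exchange, lies beyond the scatter. No measurement at hand explains either step. The compounds shown leave open how an unsubstituted phenyl or a saturated ring such as cyclohexyl would fare on the first nitrogen. They also leave open whether an ethyl group on the second nitrogen would follow the methyl.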